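The compounds below may be only part of what the source reports. "The series", "measured", "known", "first", "only" and "open" are said of these compounds alone.

The measured compounds:
Compound 1 `O=C(/C=C/c1ccc2c(c1)B(O)OC2)c1ccc(-c2ccccc2)cc1` gives 6400 nM in a functional assay on MDA-MB-231 cells (Homo sapiens) for cytotoxicity, read by MTT assay, with a stated time of 48 h; a lower number here means a stronger inhibitor, a higher number a weaker inhibitor.
Compound 2 `O=C(/C=C/c1ccc2c(c1)B(O)OC2)c1ccco1` gives 7300 nM in this assay.
Compound 3 `O=C(/C=C/c1ccc2c(c1)B(O)OC2)c1cccs1` gives 4600 nM in this assay.

All three share one core and differ only in the aromatic group attached to the carbonyl carbon. Of the three numbers, that of compound 3 is the smallest, yet its gaps to compound 1 and to compound 2 both lie within the scatter, so none of the three can be called stronger or weaker than another. Compound 4 `Cn1cccc1C(=O)/C=C/c1ccc2c(c1)B(O)OC2` varies the same place once more: 1-methyl-1H-pyrrol-2-yl in place of thiophen-2-yl on a carbonyl carbon. Among the measured compounds shown here, only one measured step bears on this kind of change, the exchange of one five-membered aromatic ring for another on the carbonyl carbon, a 1.6-fold lower number from compound 2 to compound 3 (0.20 log units; within the scatter), which stayed within the scatter. A further exchange of this kind is therefore expected to leave the number in this assay essentially unchanged, with no clear direction. For compound 4 the expected step is a 1.2-fold higher number from compound 3 to compound 4 (0.08 log units; within the scatter). The value estimated for compound 4 is 5500 nM, within a range from 2500 nM to 12000 nM.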

Compound 4, half-maximal inhibitory concentration: > 100000 nM
Compound 4 was reported as a limit; the forecaster's own chance of this, stated with the estimate: 5%; middle value at least 18-fold (1.25 log units) away from the limit.
By their numbers in this assay, from the lowest: compounds 3, 1 and 2 (each within the scatter of the next). At a limit, above all of these: compound 4.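

Compound 4 is reported only as a limit in this assay: the limit of > 100000 nM in this assay, at which 1 of the 4 values shown sits. Placing 1-methyl-1H-pyrrol-2-yl on the carbonyl carbon gives an at least 21-fold higher number from compound 3 to compound 4 (1.33 log units; beyond the scatter), and measured against the furan compound it gives an at least 13-fold higher number from compound 2 to compound 4 (1.13 log units; beyond the scatter). The earlier compounds shown here gave no sign that the aromatic group at this place mattered, whereas this result shows that exchanging one five-membered aromatic ring with 1 hetero atom for another can have a large effect, even with the same count of hydrogen-bond donors and acceptors.

The compounds shown do not separate the ring nitrogen from its methyl group, and 1H-pyrrol-2-yl, with a hydrogen on that nitrogen, would help to tell the two apart. They also leave open how a ring nitrogen without a methyl group, as in thiazol-2-yl or pyridin-2-yl, would fare here.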